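Series notes: from compound 2 to compound 3

The compounds below may be only part of what the source reports. "The series", "measured", "known", "first", "only" and "open" are said of these compounds alone.

Measured in a physicochemical assay for lipophilicity, at pH 7.4 (on this read-out lower numbers stand for lower lipophilicity and higher numbers for higher lipophilicity), so far
- compound 1 `CCc1ccc(N(CC(C)C)S(=O)(=O)c2ccc3c(c2)C(O)CC(C2CCN(C(=O)C4CCCC4)CC2)O3)cc1` gives 5.04
- compound 2 `CCc1ccc(N(CC(C)C)S(=O)(=O)c2ccc3c(c2)C(O)CC(CC2CCOCC2)O3)cc1` gives 4.44

Compound 2 (4.44) is the lower of the two measured compounds, and compound 1 (5.04) stands above it by more than the usual scatter. Within the data shown here, no measured pair differs in one place only, so no measured step is available to size the next change, and two values are a thin basis for any trend.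

Compound 3 `CCc1ccc(N(CC(C)C)S(=O)(=O)c2ccc3c(c2)C(O)CC(C2CCN(C)CC2)O3)cc1` has not yet been measured. It carries 1-methylpiperidin-4-yl in place of (oxan-4-yl)methyl on a saturated ring carbon, next to the ring oxygen (1-methylpiperidin-4-yl in place of (oxan-4-yl)methyl on a saturated ring carbon). The rest of the structure stays as in compound 2.

On the structural change alone, a downward step in this assay beyond the scatter is expected, and its size is uncertain. The estimated step is a number 1.24 log units lower from compound 2 to compound 3 (beyond the scatter) in size. For compound 3 the expected value is 3.2 (estimated range 2.5 to 3.9).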

Compound 3, distribution coefficient: 2.67
Compound 3: middle estimate off by 0.53 log units, on the high side; measured number inside the range.
By their numbers in this assay, from the lowest: compound 3; then compound 2; then compound 1.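

In this assay, compound 3 now has two one-place steps leading to it, and both are large: 1-methylpiperidin-4-yl in place of (oxan-4-yl)methyl on the saturated ring carbon next to the ring oxygen gives a number 1.77 log units lower from compound 2 to compound 3 (beyond the scatter), while methyl in place of cyclopentylcarbonyl on the amine nitrogen in the ring gives a number 2.37 log units lower from compound 1 to compound 3 (beyond the scatter). In the first exchange, the leaving and entering groups have the same counts of heavy atoms, hydrogen-bond donors and hydrogen-bond acceptors, and neither carries a net charge, so these counts do not separate the two groups even though the step in this assay is beyond the scatter. No measurement available here bears on the reason for either step.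

The compounds shown do not separate the exchange of ring oxygen for ring nitrogen from the change in how the ring is attached, a question that oxan-4-yl or (1-methylpiperidin-4-yl)methyl at the same carbon would address. As far as these compounds go, how this assay responds to groups of intermediate size on the ring nitrogen, such as acetyl or a longer chain like propyl, also remains open.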